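From Compound 3 to Compound 4: Fluoro for Chloro

The source may report more compounds than this note shows. Statements on the series, on what has been measured and on what is new or still open speak of the compounds shown alone.

Measured in a functional assay on HeLa cells for agonist activity at 5-hydroxytryptamine receptor 6 (Homo sapiens), read by cAMP accumulation and immunoassay; on this read-out lower numbers stand for an effect already at smaller amounts and higher numbers for an effect only at larger amounts of compound:
compound 1 `CN1CCC(n2cc(S(=O)(=O)c3cccc(F)c3)c3cccnc32)C1` — 231 nM
compound 2 `O=S(=O)(c1ccccc1)c1cn(C2CCCNC2)c2ncccc12` — 47 nM
compound 3 `O=S(=O)(c1cccc(Cl)c1)c1cn(C2CCCNC2)c2ncccc12` — 30 nM

Compound 3 gives the lowest of the three numbers, but its gap to compound 2 is small: a 1.6-fold lower number from compound 2 to compound 3 (0.19 log units; within the scatter). Compound 1, with a different amine and a fluoro already on its phenyl ring, stands far higher. Compound 4 `O=S(=O)(c1cccc(F)c1)c1cn(C2CCCNC2)c2ncccc12` is reached from compound 3 by fluoro in place of chloro on an aromatic carbon, on an aromatic carbon of a six-membered aromatic ring of carbon only, meta to a large group. Going by the values given here, the only step bearing on this position, hydrogen to chloro in a 1.6-fold lower number from compound 2 to compound 3 (0.19 log units; within the scatter), lay within the scatter, so no step beyond the scatter is expected here either. Compound 4 is expected near 40 nM, between 18 nM and 90 nM. The expected step is a 1.3-fold higher number from compound 3 to compound 4 (0.12 log units; within the scatter).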

Compound 4, half-maximal effective concentration: 67 nM
The estimate for compound 4 lay 1.7-fold (0.22 log units) below the measured number, and the stated range covers the measured number.
By their numbers in this assay, from the lowest: compounds 3, 2 and 4 (each within the scatter of the next, the first and the last beyond it); then compound 1.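

In this assay, the two halogens at this position can now be told apart (a 2.2-fold higher number from compound 3 to compound 4 (0.35 log units; beyond the scatter)), although neither chloro (a 1.6-fold lower number from compound 2 to compound 3 (0.19 log units; within the scatter)) nor fluoro (a 1.4-fold higher number from compound 2 to compound 4 (0.15 log units; within the scatter)) separates from hydrogen. Going by these compounds alone, with the 3-fluorophenyl group held constant, the amine change also gives a step beyond the scatter (a 3.4-fold lower number from compound 1 to compound 4 (0.54 log units; beyond the scatter)), which the earlier compounds, differing in two places, could not show. No measurement offered here accounts for either step.
The compounds shown leave open how methoxy or nitrile would fall at this position. They also leave open whether 1-methylpiperidin-3-yl would stand with compound 1 or compound 4.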